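A few compounds are considered here, and "the series" means these few. Any claim that something is new, unique, unknown or untested is made for them only; others in the source may bear on it.

For the measured compounds named here, compound 2 `O=C(NC(=S)N1CCc2c(OCCCCCOc3ccc(Cl)cc3)cccc21)c1ccc(Cl)cc1` is the one compound here with a number in an ADME assay on Huh-7 cells (Homo sapiens) for cytotoxicity; a lower number here means that less compound is tolerated, a higher number that more compound is tolerated. In this assay compound 2 gives 21700 nM. Compound 1 `O=C(NC(=S)N1CCc2cccc(OCc3ccccc3)c21)c1ccccc1` reaches only the limit of this assay, giving > 50000 nM. Compound 3 `O=C(NC(=S)N1CCc2c(OCCCCCOc3ccc(Cl)cc3)cccc21)c1ccco1` differs from compound 2 by a single change: furan-2-yl in place of 4-chlorophenyl on a carbonyl carbon. Going by the values given here, no measured pair shows a change of this kind, so the size of the step can only be guessed from the structures. The step of a 1.6-fold higher number from compound 2 to compound 3 (0.21 log units; within the scatter) is expected to be a modest rise, perhaps just beyond the scatter, moving toward the limit (the limit of > 50000 nM in this assay, at which 1 of the 2 values shown sits). Compound 3 is therefore estimated at 35000 nM, within 15000 nM to 80000 nM.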

Compound 3, half-maximal cytotoxic concentration: 4620 nM
Beside the measured number, compound 3's estimate is 7.6-fold (0.88 log units) above it, and the stated range ends above it.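

In this assay, for the compounds shown here, furan-2-yl in place of 4-chlorophenyl on a carbonyl carbon gives a 4.7-fold lower number from compound 2 to compound 3 (0.67 log units; beyond the scatter) and is the first measured sign that this position alone can shift the number beyond the scatter. The smaller ring, which carries an oxygen, gives the lower number of this pair. Nothing measured here accounts for the direction of this step.

A thiophen-2-yl or pyridin-3-yl group on the same carbonyl carbon could show whether the step goes with the furan oxygen or with the loss of 4-chlorophenyl. This single pair also leaves open whether the step would hold with a different chain on the shared core.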